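A Furan for a Thiophene on the Shared Core

The compounds below may be only part of what the source reports. "The series", "measured", "known", "first", "only" and "open" are said of these compounds alone.

Of the compounds shown here, three built on one shared core have been tested in an assay on HeLa cells for displacement of a labelled ligand from adenosine receptor A3 (Homo sapiens), with a stated time of 180 min, tested at 1 uM; on this read-out lower numbers stand for less inhibition and higher numbers for more inhibition at the one concentration tested (going by the name of the read-out). Compound 1 `CC1=C(C(=O)OC(C)C)[C@H](c2ccco2)N/C(=N/C#N)N1` gives 1%, compound 2 `CCOC(=O)C1=C(C)N/C(=N\C#N)NC1c1ccsc1` gives 23%, and compound 3 `CC1=C(C(=O)OC(C)C)C(c2ccccc2)N/C(=N/C#N)N1` gives 6%. Among these three numbers compound 2 stands highest; its nearest neighbour is compound 3, and the gap to it lies beyond the usual scatter, as does the larger gap to compound 1. No pair of these compounds differs in a single place, so none of the gaps can be tied to one structural change.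

Compound 4 `CCOC(=O)C1=C(C)N/C(=N\C#N)NC1c1ccco1` has not yet been measured. It differs from compound 2 in one place: furan-2-yl in place of thiophen-3-yl on a saturated ring carbon. The rest of the shared core, including the ethoxycarbonyl group and the methyl group, is unchanged.

Among the measured compounds shown here, nothing measured so far isolates this change. What can be said is that compound 1, which also carries the furan-2-yl group but a different ester, gives 1%, the lowest of the three numbers. On that basis the step from compound 2 to compound 4 is expected to go downward, at a size of about a number 15 percentage points lower from compound 2 to compound 4 (beyond the scatter). For compound 4 an inhibition of roughly 8% is estimated in this assay, with a range from 0% to 25%.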

Compound 4, a percentage reported as inhibition, at one concentration (the size of the read-out at that concentration, not a potency): 20%
For compound 4 the middle estimate is 12 percentage points below the measured one; low and high end bracket the measured number.
By their numbers in this assay, from the lowest: compounds 1 and 3 (each within the scatter of the next); then compounds 4 and 2 (each within the scatter of the next).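

Among the compounds shown here, this is the first direct reading of a single change on the shared core: in this assay, placing furan-2-yl instead of thiophen-3-yl on the saturated ring carbon gives a number 3 percentage points lower from compound 2 to compound 4 (within the scatter). With the ethoxycarbonyl and methyl groups held fixed, this read-out therefore does not separate the two groups at this position, although one five-membered aromatic ring carries sulfur and the other oxygen, and a furan-2-yl group on this core need not come with a number at the low end of the series. Nothing at hand explains why the two groups read alike here.

On these data alone, whether the same exchange would read the same way alongside the ester of compound 1 remains open, and a single concentration shows the size of the inhibition at that concentration, not a potency, so any difference in potency between the two groups also remains unknown. As far as these compounds go, it is equally open how the number would respond to a group of a different kind on this saturated ring carbon, such as an amine, a carboxylic acid or a longer chain.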